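The source may hold more compounds than are shown below. What is called first, only, known or untested is meant among the compounds shown, and "the series" means these compounds.

Measured in a functional assay on A375M cells (Homo sapiens) for cytotoxicity, read by MTT assay, with a stated time of 4 days; on this read-out lower numbers stand for stronger inhibition and higher numbers for weaker inhibition:
- compound 1 `C=C1C(=O)OC(CCCCCCCCCCCCC)C1CCc1ccccc1`: 3300 nM
- compound 2 `C=C1CC(c2ccccc2)OC1=O`: 6700 nM
- compound 3 `C=C1CC(CCc2ccccc2)OC1=O`: 8700 nM

Compound 2 lies within the scatter of compound 3 and beyond the scatter of compound 1, which has the lower number. Compound 4 `C=C1C(=O)OC(c2ccccc2)C1c1ccccc1` has phenyl in place of hydrogen on a saturated ring carbon of compound 2 (phenyl in place of hydrogen on a saturated ring carbon). For the measured compounds named here, no measured pair isolates this change, so the expectation is weakly grounded. It rests on compound 1, which is also substituted at two ring carbons and gives 3300 nM. In this assay, a small move towards a lower number is expected, possibly none beyond the scatter, as the estimated 1.7-fold lower number from compound 2 to compound 4 (0.22 log units; within the scatter). The estimate for compound 4 is 4000 nM, with an expected range of 1500 nM to 10000 nM.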

Compound 4, half-maximal inhibitory concentration: 6300 nM
Compound 4: the middle estimate sits 1.6-fold (0.20 log units) below what was measured; measured number inside the range.
By their numbers in this assay, from the lowest: compounds 1, 4, 2 and 3 (each within the scatter of the next, the first and the last beyond it).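

In this assay, for the compounds shown here, phenyl in place of hydrogen on a saturated ring carbon gives a 1.1-fold lower number from compound 2 to compound 4 (0.03 log units; within the scatter), the first step that isolates one change. This ring carbon, two ring bonds from the ring oxygen, therefore accepts a phenyl group, with compound 4 lying within the scatter of compound 2. No available evidence accounts for this result. Still open, going by these compounds, is whether a methyl group, an amine or a carboxylic acid on this ring carbon would also lie within the scatter of compound 2.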